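A boron-bearing group replaces the hydroxycarbamoyl of compound 2

The source may hold more compounds than are shown below. What is called first, only, known or untested is meant among the compounds shown, and "the series" means these compounds.

Compound 1, `O=C(NCc1ccc(OCc2ccccc2)cc1)[C@@H]1CCC(=O)N1Cc1ccccc1`; compound 2, `O=C(NO)c1ccc(COc2ccc(CNC(=O)[C@@H]3CCC(=O)N3Cc3ccccc3)cc2)cc1`.

In an assay on HEK293 cells for inhibition of Ataxin-2 (Mus musculus), read by fluorescence and Amplex Red (a higher number here means a weaker inhibitor, a lower number a stronger inhibitor), compound 1 gives > 5000 nM, a limit of the assay rather than a number. Compound 2 gives 700 nM, the only number shown. The step of an at least 7.1-fold lower number from compound 1 to compound 2 (0.85 log units; beyond the scatter) shows that the hydroxycarbamoyl carries the measurable inhibition. Compound 3, `O=C(NCc1ccc(OCc2ccc(B(O)O)cc2)cc1)[C@@H]1CCC(=O)N1Cc1ccccc1`, differs from compound 2 by a group of 3 heavy atoms (1 boron, 2 oxygen; no ring) in place of a group of 4 heavy atoms (1 carbon, 1 nitrogen, 2 oxygen; no ring), on an aromatic carbon. From the compounds shown here alone, whether the entering group can replace what the hydroxycarbamoyl gave is untested; the account expects a step of a 4.3-fold higher number from compound 2 to compound 3 (0.63 log units; beyond the scatter) toward a higher number. Compound 3 is therefore estimated at 3000 nM, expected between 800 nM and 10000 nM.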

Compound 3, half-maximal inhibitory concentration: 35 nM
For compound 3 the middle estimate is 86-fold (1.93 log units) above the measured one; measured number outside the range, below it.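

In this assay, the boron-bearing group gives a 20-fold lower number from compound 2 to compound 3 (1.30 log units; beyond the scatter), so inhibition at this aromatic carbon, para to a large group, does not depend on the hydroxycarbamoyl. Set against the hydrogen atom, the same group gives an at least 140-fold lower number from compound 1 to compound 3 (2.15 log units; beyond the scatter). That step rests on a limit of the assay and not on a number: the limit of > 5000 nM in this assay, at which 1 of the 3 values shown sits.

The compounds shown leave open whether a carboxylic acid on this carbon would match the boron-bearing group. They also leave open whether a longer chain carrying the boron would keep the low number.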